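From Benzyl to Cyclopropylcarbonylmethyl on a Sulfur Chain

The compounds below may be only part of what the source reports. "The series", "measured", "known", "first", "only" and "open" are said of these compounds alone.

Measured so far:
Compound 1 `COc1ccc(-n2c(S)nnc2-c2cc(OC)c(OC)c(OC)c2)cc1`: in a functional assay on HCT-116 cells (Homo sapiens) for inhibition, read by MTT assay, with a stated time of 48 h (a lower number here means a stronger inhibitor, a higher number a weaker inhibitor), compound 1 gives > 60000 nM, which is a limit of the assay.
Compound 2 `COc1ccc(-n2c(SCc3ccccc3)nnc2-c2cc(OC)c(OC)c(OC)c2)cc1`: in this assay compound 2 gives 42400 nM.
Compound 3 `COc1ccc(-n2c(SCC(=O)c3ccccc3)nnc2-c2cc(OC)c(OC)c(OC)c2)cc1`: in this assay compound 3 gives > 60000 nM, which is a limit of the assay.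

Compound 2 is the only one of the three whose result is a number at all; the other two sit at the assay's ceiling (the limit of > 60000 nM in this assay, at which 2 of the 3 values shown sit), so compound 2 is the lone anchor for any comparison. Compound 4 `COc1ccc(-n2c(SCC(=O)C3CC3)nnc2-c2cc(OC)c(OC)c(OC)c2)cc1` has not yet been measured. It differs from compound 2 in one place: cyclopropylcarbonyl in place of phenyl on a saturated chain carbon bound to a sulfur.

One measured step speaks to this change. Going from compound 2 to compound 3, a carbonyl enters at the same place, and the result is an at least 1.4-fold higher number from compound 2 to compound 3 (0.15 log units; that floor lies within the scatter). Compound 4 brings in a carbonyl in just the same way, with a small three-membered ring in place of the aromatic ring of compound 3. The expectation is therefore a higher number, quite possibly reaching the limit again, as an expected step of a 1.8-fold higher number from compound 2 to compound 4 (0.25 log units; within the scatter). Compound 4 is thus expected to give about 75000 nM, with a range from 30000 nM to 180000 nM.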

Compound 4, half-maximal inhibitory concentration: > 60000 nM
Compound 4 was reported as a limit; the forecaster's own chance of this, stated with the estimate: 60%; the middle value is on the limit's open side.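

Replacing phenyl with cyclopropylcarbonyl on the saturated chain carbon bound to the sulfur gives an at least 1.4-fold higher number from compound 2 to compound 4 (0.15 log units; that floor lies within the scatter), so this step alone does not establish a real loss in this assay. What is new is that a carbonyl chain ending in a small non-aromatic ring now joins the one ending in an aromatic ring: among the compounds with a group on the sulfur, only the benzyl compound, compound 2, gives a number, while compound 3 and compound 4 do not, and compound 1, with hydrogen on the sulfur, also gives no number and so stands outside this comparison. No order can be drawn among compound 1, compound 3 and compound 4, because each step among them joins two limits and cannot be read: the limit of > 60000 nM in this assay, at which 3 of the 4 values shown sit.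

From the compounds shown here alone, how far compound 4 actually lies from compound 2 remains unknown, since only a floor is available for that step. Also open, going by these compounds, is whether a sulfur chain ending in an amine or a carboxylic acid, or a longer carbon chain in place of benzyl, would give a measurable number in this assay, and how that number would compare with that of compound 2, which gives 42400 nM.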